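The compounds below may be only part of what the source reports. "The series", "measured", "known", "first", "only" and "open" are said of these compounds alone.

Compound 2 `COc1cc(C(=O)N2CCC(O)C(C)C2)cc2nc(NCc3cc(Cl)ccn3)oc12` is the weaker of the two measured compounds: in an assay on isolated protein for inhibition of thyroid hormone receptor beta (Homo sapiens), read by fluorescence, with a stated time of 30 min (a lower number here means a stronger inhibitor, a higher number a weaker inhibitor), compound 2 gives 190 nM, the highest of the two numbers, while compound 1 `COc1cc(C(=O)N2CC[C@@H](O)[C@H](C)C2)cc2nc(NCc3cccc(Cl)c3)oc12` gives 10 nM in this assay, a gap that lies beyond the usual scatter. The two differ in more than one place, so only the two values themselves can be compared. Compound 3 `COc1cc(C(=O)N2CCC(O)C(C)C2)cc2nc(NCc3ccnc(Cl)c3)oc12` carries the same atoms as compound 2, joined differently: 2-chloropyridin-4-yl in place of 4-chloropyridin-2-yl on a saturated chain carbon bound to a nitrogen on an aromatic ring. Within the data shown here, no measured pair shows the effect of such a swap on its own. The result for compound 3 is therefore expected to stay close to that of compound 2, with a modest step from a 1.6-fold lower number from compound 2 to compound 3 (0.20 log units; within the scatter) that may not exceed the scatter. Compound 3 is estimated at 120 nM in this assay, within a range from 30 nM to 500 nM.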

Compound 3, half-maximal inhibitory concentration: 6900 nM
Compound 3: middle estimate off by 58-fold (1.76 log units), on the low side; measured number outside the range, above it.
By their numbers in this assay, from the lowest: compound 1; then compound 2; then compound 3.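

In this assay, replacing 4-chloropyridin-2-yl by 2-chloropyridin-4-yl on a saturated chain carbon bound to a nitrogen on an aromatic ring gives a large change, a 36-fold higher number from compound 2 to compound 3 (1.56 log units; beyond the scatter), although the two groups have the same atoms and the same counts of donors and acceptors. This position therefore distinguishes between two groups of identical composition, something the earlier pair, which differed in more than one place, could not show. Nothing available accounts for the size of this step.

The compounds shown leave open whether the chlorine itself matters, as an unsubstituted pyridinyl group or a nitrile in place of the chlorine would show. Going by these compounds, it also remains open whether the same step would appear with the amide part of compound 1, which differs from compound 2 and compound 3 in more than one place.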